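Hydrazone series on a shared core: demethylation of compound 2

A few compounds are considered here, and "the series" means these few. Any claim that something is new, unique, unknown or untested is made for them only; others in the source may bear on it.

Measured compounds in a functional assay on HCT-116 cells (Homo sapiens) for cytotoxicity, read by MTT assay, with a stated time of 3 days; a lower number here means a stronger inhibitor, a higher number a weaker inhibitor:
compound 1 `CN(C)Cc1ccc(/C=N/Nc2ncnc3sc(C(C)(C)C)cc23)cc1`: 0.128 ug/mL
compound 2 `CN1Cc2ccc(/C=N/Nc3ncnc4sc(C(C)(C)C)cc34)cc2C1`: 0.088 ug/mL
compound 3 `COC(=O)c1ccc(/C=N/Nc2ncnc3sc(C(C)(C)C)cc23)cc1`: "not determined" (no result reported)

Compound 2 shows the lowest of the two numbers, but the gap to compound 1 is within the scatter, so the two are not told apart; compound 3 carries no number. Compound 4 `CC(C)(C)c1cc2c(N/N=C/c3ccc4c(c3)CNC4)ncnc2s1` is the next entry. Relative to compound 2 the change is hydrogen in place of methyl on an amine nitrogen in a ring. Going by the values given here, no step between measured compounds involves this position, so there is nothing to anchor the size of the effect. With a single small change at a ring amine, the expected step of a 1.3-fold higher number from compound 2 to compound 4 (0.10 log units; within the scatter) is none beyond the scatter, with a slight lean toward a weaker number. Compound 4 is estimated at 0.11 ug/mL, between 0.045 ug/mL and 0.27 ug/mL.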

Compound 4, half-maximal inhibitory concentration: 0.111 ug/mL
Compound 4: the middle estimate sits 1.0-fold (0.00 log units) below what was measured; low and high end bracket the measured number.
By their numbers in this assay, from the lowest: compounds 2, 4 and 1 (each within the scatter of the next).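

In this assay, hydrogen in place of methyl on an amine nitrogen in a ring gives a 1.3-fold higher number from compound 2 to compound 4 (0.10 log units; within the scatter) and so stays within the scatter. Going by these compounds alone, this is the first step read at this position, and at this ring amine the methyl and the hydrogen are not told apart. No available evidence bears on this step.

Still open, going by these compounds, is whether an ethyl or acetyl group on this nitrogen would also stay within the scatter. On these data alone, a longer chain ending in a carboxylic acid is equally open.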